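Methylating the ring nitrogen of compound 2

A few compounds are considered here, and "the series" means these few. Any claim that something is new, unique, unknown or untested is made for them only; others in the source may bear on it.

In a functional assay on A549 cells (Homo sapiens) for inhibition, read by MTT assay, with a stated time of 72 h, tested at 20 uM (a lower number here means less inhibition, a higher number more inhibition at the concentration tested (going by the name of the read-out)), compound 2 `c1ccc2c(c1)CCN2c1ccnc(Nc2ccc(Oc3ncnc4sccc34)cc2)n1` gives 2.81%, the lowest of the two numbers in hand. In this assay compound 1 `CN(c1ccc(Oc2ncnc3sccc23)cc1)c1nccc(N2CCCCC2)n1` gives 51.9%; compound 1 and compound 2 differ in more than one place, so their gap cannot be assigned to a single change. Compound 3 `CN(c1ccc(Oc2ncnc3sccc23)cc1)c1nccc(N2CCc3ccccc32)n1` differs from compound 2 by methyl in place of hydrogen on a nitrogen on an aromatic ring. The step is expected to go upward because compound 1 gives 51.9% with that methyl in place, though the second difference between compound 1 and compound 2 leaves the size uncertain. Compound 3 is therefore estimated at 30% (range 5% to 60%), an expected step of a number 27.2 percentage points higher from compound 2 to compound 3 (beyond the scatter).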

Compound 3, a percentage reported as inhibition, at one concentration (the size of the read-out at that concentration, not a potency): 29.4%
Compound 3: middle estimate off by 0.6 percentage points, on the high side, and the stated range covers the measured number.
By their numbers in this assay, from the lowest: compound 2; then compound 3; then compound 1.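

In this assay, methyl in place of hydrogen on the nitrogen on an aromatic ring gives a number 26.6 percentage points higher from compound 2 to compound 3 (beyond the scatter), so this single change, with 2,3-dihydro-1H-indol-1-yl held constant, moves the read-out beyond the scatter. With that methyl held constant, 2,3-dihydro-1H-indol-1-yl in place of piperidin-1-yl on an aromatic carbon gives a number 22.5 percentage points lower from compound 1 to compound 3 (beyond the scatter), so the second place also carries a step of its own. Nothing available explains either step. As far as these compounds go, whether ethyl or a longer alkyl chain on that nitrogen would move the read-out further remains open, as does the size of the methyl step with piperidin-1-yl in place.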